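Trifluoromethylphenyl ether in a bicyclic thiazole acid series

The source may report more compounds than this note shows. Statements on the series, on what has been measured and on what is new or still open speak of the compounds shown alone.

Working notes on a set of bicyclic thiazole carboxylic acids carrying an aryl ether side chain, tested in an assay on HEK293 cells for agonist activity at prostaglandin E2 receptor EP2 subtype (Homo sapiens), read by a beta-galactosidase reporter and beta-arrestin recruitment, with a stated time of 90 min; on this read-out higher numbers stand for an effect only at larger amounts of compound and lower numbers for an effect already at smaller amounts. Compound 1 `Cc1cccc(OC[C@@H]2[C@H]3CC[C@H](c4nc(C(=O)O)cs4)O[C@H]3C[C@H]2O)c1` bears a 3-methylphenyl ether. In this assay compound 1 gives > 10000 nM, which is a limit of the measurement and not a number. Compound 2 `O=C(O)c1csc([C@H]2CC[C@@H]3[C@@H](/C=C/CCOc4ccccc4)[C@H](O)C[C@@H]3O2)n1` carries its phenyl ether on an unsaturated linker; in this assay compound 2 also gives > 10000 nM, again only a limit. Among the measured compounds shown here, both values shown thus sit at the same point (the limit of > 10000 nM in this assay, at which 2 of the 2 values shown sit), so compound 1 stands at the edge of what the assay resolves, with no measured step to compare against.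

Compound 3 `O=C(O)c1csc([C@H]2CC[C@@H]3[C@@H](COc4ccc(C(F)(F)F)cc4)[C@H](O)C[C@@H]3O2)n1` differs from compound 1 in one place: 4-(trifluoromethyl)phenyl in place of 3-methylphenyl on an oxygen on a saturated carbon. For the measured compounds named here, because every value so far is the limit (the limit of > 10000 nM in this assay, at which 2 of the 2 values shown sit), no direction beyond the scatter is expected from this change. For compound 3 the estimated value is 10000 nM, with a range from 2000 nM to 50000 nM, an expected step of a number no higher from compound 1 to compound 3 (the limit leaves the size open) that is most likely reported as a limit once more.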

Compound 3, half-maximal effective concentration: > 10000 nM
Compound 3: a limit, no number; the forecaster's own chance of this, stated with the estimate: 80%; the middle value sits exactly at the limit.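

The step from compound 1 to compound 3 cannot be read, since the values of both compounds are limits and not numbers: the limit of > 10000 nM in this assay, at which 3 of the 3 values shown sit.

The compounds shown leave open whether any change to the aryl ether gives a measurable effect in this assay at all.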